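From 2-aminobutyl to 2-amino-3-methylbutyl in compound 3

The source may hold more compounds than are shown below. What is called first, only, known or untested is meant among the compounds shown, and "the series" means these compounds.

Compound 1 `CC(C)n1cnc2c(NC(=N)N)nc(NCCCO)nc21`: 8800 nM
Compound 2 `CC[C@@H](N)COc1nc(NC(=N)N)c2ncn(C(C)C)c2n1`: > 100000 nM, a limit

In a functional assay on MCF7 cells (Homo sapiens) for inhibition, read by fluorescence, with a stated time of 72 h (on this read-out lower numbers stand for stronger inhibition and higher numbers for weaker inhibition), compound 2 stands at the limit of > 100000 nM in this assay, at which 1 of the 2 values shown sits. Compound 3 `CC(C)[C@@H](N)COc1nc(NC(=N)N)c2ncn(C(C)C)c2n1` differs from compound 2 by methyl in place of hydrogen on a saturated chain carbon bound to two saturated chain carbons, turning ethyl into isopropyl. Within the data shown here, the only measured step is an at least 11-fold higher number from compound 1 to compound 2 (1.05 log units; beyond the scatter). That large step replaced a different group, so it sets no size for this change. No step beyond the scatter is therefore expected in this assay, and a result at the limit is likely. The expected change is a number no higher from compound 2 to compound 3 (the limit leaves the size open). Compound 3 is estimated at 100000 nM, within an expected range of 30000 nM to 200000 nM.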

Compound 3, half-maximal inhibitory concentration: 79400 nM
Beside the measured number, compound 3's estimate is 1.3-fold (0.10 log units) above it; the range from low to high includes it.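

In this assay, replacing ethyl with isopropyl gives compound 3 a measured number, and the step is an at least 1.2-fold lower number from compound 2 to compound 3 (0.10 log units; that floor lies within the scatter). Compound 2 holds only a limit: the limit of > 100000 nM in this assay, at which 1 of the 3 values shown sits. Even so, the 2-amino-3-methylbutoxy group does not match the (3-hydroxypropyl)amino group, the change being a 9.0-fold higher number from compound 1 to compound 3 (0.96 log units; beyond the scatter).

Still open, as far as these compounds go, is how a longer chain or a phenyl group would read in place of the isopropyl in this assay. Also open, from the compounds shown here alone, is whether a hydroxyl in place of the amine on the 2-amino-3-methylbutoxy chain would bring the number closer to that of compound 1.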